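Swapping the Aryl Group on the Amine Nitrogen

The source may hold more compounds than are shown below. What is called first, only, known or untested is meant among the compounds shown, and "the series" means these compounds.

Measured in a functional assay on MCF7 cells (Homo sapiens) for cytotoxicity, read by sulforhodamine B assay; a lower number here means a stronger inhibitor, a higher number a weaker inhibitor:
- Compound 1 `C=C1[C@@H](OC(C)=O)C[C@@H]2[C@](C)(COC=O)[C@H](OC(C)=O)CC[C@@]2(C)[C@@H]1C[C@@H](Nc1ccccc1C(=O)O)C1=CCOC1=O`: 30800 nM
- Compound 2 `C=C1[C@@H](OC(C)=O)C[C@@H]2[C@](C)(CO[Si](C)(C)C(C)(C)C)[C@H](OC(C)=O)CC[C@@]2(C)[C@@H]1C[C@@H](Nc1ccccc1C(=O)O)C1=CCOC1=O`: 4460 nM

Of these two compounds, compound 2 has the lower number and is therefore the stronger inhibitor here. For the measured compounds named here, the only measured step, a 6.9-fold lower number from compound 1 to compound 2 (0.84 log units; beyond the scatter), comes from a change to a group on an oxygen on a saturated carbon.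

The next molecule, compound 3 `C=C1[C@@H](OC(C)=O)C[C@@H]2[C@](C)(CO[Si](C)(C)C(C)(C)C)[C@H](OC(C)=O)CC[C@@]2(C)[C@@H]1C[C@@H](Nc1cccc(OC)c1)C1=CCOC1=O`, keeps that group from compound 2 but changes another part of the structure: 3-methoxyphenyl in place of 2-carboxyphenyl on an amine nitrogen. Put simply, 3-methoxyphenyl stands in place of 2-carboxyphenyl on an amine nitrogen.

Going by the values given here, no measured pair tests a change at this nitrogen, so the data do not settle the direction. Among the compounds with values here, the one available step shows only how far a single change moved the number. Starting from compound 2 at 4460 nM, a small shift with a slight lean towards a lower number is expected. The expected change is a 1.3-fold lower number from compound 2 to compound 3 (0.11 log units; within the scatter). For compound 3, the estimated value is 3500 nM, with an expected range of 1200 nM to 10000 nM.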

Compound 3, half-maximal inhibitory concentration: 28100 nM
The estimate for compound 3 lay 8.0-fold (0.90 log units) below the measured number, outside the stated range (above it).
By their numbers in this assay, from the lowest: compound 2; then compounds 3 and 1 (each within the scatter of the next).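

In this assay, a 6.3-fold higher number from compound 2 to compound 3 (0.80 log units; beyond the scatter) shows that the aryl group on this amine nitrogen also affects the number, whereas the earlier step showed only the effect of a change to the group on oxygen. Of the two groups compared here, 2-carboxyphenyl gives the stronger inhibitor, with the silyl-bearing side of the molecule held constant. The swap alters several features at once: the hydrogen-bond donor and the double bond outside the ring leave with 2-carboxyphenyl, and the ring carries a different group at a different place, while no measurement here explains the loss of activity.

The compounds shown leave open which of those features matters, and a plain phenyl group on the same nitrogen, or a phenyl ring carrying an amide instead of the carboxylic acid, would help separate them. They also leave open whether 3-methoxyphenyl would have the same effect alongside the smaller group on oxygen found in compound 1.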